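The compounds below may be only part of what the source reports. "The series", "measured", "known", "first", "only" and "open" are said of these compounds alone.

Measured so far:
compound 1 `O=[N+]([O-])c1ccccc1CNc1cccc2[nH]ncc12`: 87%
compound 2 `Nc1cccc(CNc2cc(C(F)(F)F)cc3[nH]ncc23)c1`: 89%

In an assay for inhibition of Tryptophan 2,3-dioxygenase (Homo sapiens), with stated times of 10 min and 60 min, tested at 100 uM (a higher number here means a stronger effect of the compound at the concentration tested, a lower number a weaker effect), compound 1 gives 87%, the lower of the two numbers shown, but compound 2 gives 89% and that gap lies within the usual scatter, so neither stands apart. Compound 3 `O=[N+]([O-])c1ccccc1CNc1cc(C(F)(F)F)cc2[nH]ncc12` differs from compound 1 by trifluoromethyl in place of hydrogen on an aromatic carbon. Going by the values given here, no measured pair shows this change alone, yet compound 2 also carries a trifluoromethyl and its number is close to that of compound 1. The step from compound 1 to compound 3 in this assay is therefore expected to be small, in either direction, or none beyond the scatter. Compound 3 is expected to give 88%, within 76% to 96%, an expected step of a number 1 percentage points higher from compound 1 to compound 3 (within the scatter).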

Compound 3, a percentage reported as inhibition, at one concentration (the size of the read-out at that concentration, not a potency): 95%
For compound 3 the middle estimate is 7 percentage points below the measured one; low and high end bracket the measured number.
By their numbers in this assay, from the lowest: compounds 1, 2 and 3 (each within the scatter of the next).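

In this assay, going by these compounds alone, the pair gives a number 8 percentage points higher from compound 1 to compound 3 (within the scatter) and this is the only direct reading of trifluoromethyl in place of hydrogen on this aromatic carbon, para to a fused ring. With the change alone in view, the read-out stays within the scatter of compound 1, though a single concentration gives no potency. Nothing measured here offers a reason for this result. The compounds shown leave open whether an amine, a nitrile or a carboxylic acid at this place would read alike, and whether trifluoromethyl would do so on another carbon of the shared core.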